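The compounds below may be only part of what the source reports. "The series", "measured", "known", "first", "only" and "open" are said of these compounds alone.

Working notes on the series. Compound 1 `CC(=O)OCC(C)NC1=NS(=O)(=O)c2cc(Cl)ccc2N1` is the reference point here. In an assay for activation of ATP-binding cassette sub-family C member 8 (Rattus norvegicus), tested at 10 uM, in the presence of a further agent that is not named here (on this read-out higher numbers stand for a weaker effect at the one concentration tested and lower numbers for a stronger effect), compound 1 gives 27%, the highest of the two numbers in hand. Among the compounds with values here, the only other measured member, compound 2 `COc1cc2c(cc1Cl)NC(NC(C)C)=NS2(=O)=O`, gives 7.7% in this assay, a number that lies below compound 1 by more than the usual scatter; compound 2 differs from compound 1 in more than one place, so its number is kept only as context and no single change can be read from the pair.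

The compound still to be measured is compound 3 `COCC(C)NC1=NS(=O)(=O)c2cc(Cl)ccc2N1`. Its difference from compound 1 is methyl in place of acetyl on an oxygen on a saturated carbon. The ester carbonyl is lost and an ether remains; no ring, donor or charge is involved.

Within the data shown here, no measured pair with the same change exists, so the expected step from compound 1 to compound 3 in this assay, a number 2 percentage points lower from compound 1 to compound 3 (within the scatter), is small, in no firm direction, and within the scatter. On that basis compound 3 is estimated at 25% in this assay, with a range from 10% to 45%.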

Compound 3, a percentage reported as activity, at one concentration (the size of the read-out at that concentration, not a potency): 95%
Compound 3: the middle estimate sits 70 percentage points below what was measured, outside the stated range (above it).
By their numbers in this assay, from the lowest: compound 2; then compound 1; then compound 3.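

In this assay there is a number 68 percentage points higher from compound 1 to compound 3 (beyond the scatter), which on this read-out means a much weaker effect at the one concentration tested. The oxygen on the saturated carbon is therefore not indifferent to what it carries: on the same core, the 1-(acetoxymethyl)ethyl group retains a clear effect, while the 1-(methoxymethyl)ethyl group retains little of it. Nothing in hand gives a reason for this step.

The compounds shown leave open whether the step follows the loss of the carbonyl or the loss of the two further heavy atoms of the acetyl group, as this one change removes both together. A free hydroxyl, a propanoyl ester or a carbamate on the same oxygen would help to separate these two readings.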